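This account rests on a few compounds, and the source may have more. Where it says the series, first, only, none or still open, it means among the compounds named here.

Measured compounds:
Compound 1, `Fc1ccc2[nH]c(-c3nc(-c4ccc(Cl)cc4)no3)cc2c1`: in a functional assay on Jurkat cells (Homo sapiens) for antiproliferative activity, read by WST assay, with a stated time of 72 h (on this read-out higher numbers stand for weaker inhibition and lower numbers for stronger inhibition), compound 1 gives > 50000 nM, which is a limit of the assay, not a number.
Compound 2, `COc1ccc(-c2noc(-c3cc4cc(OC)ccc4[nH]3)n2)cc1`: in this assay compound 2 gives > 50000 nM, again a limit rather than a number.

Going by the values given here, compound 2 therefore stands where the only other value stands: both sit at the limit of > 50000 nM in this assay, at which 2 of the 2 values shown sit, so neither compound shows measurable inhibition of Jurkat cell growth within the tested range.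

Compound 3, `COc1ccc(-c2noc(-c3cc4cc(F)ccc4[nH]3)n2)cc1`, is still to be measured. It differs from compound 2 by fluoro in place of methoxy on an aromatic carbon, so fluoro takes the place of methoxy on an aromatic carbon of the fused two-ring part of the shared core, while the methoxy-bearing phenyl on the other side of the core stays as in compound 2.

Among the compounds with values here, no step between measured compounds is available, so there is no measured change of this kind to lean on. The expectation is that the step from compound 2 to compound 3 brings no change beyond the scatter, and that compound 3 most likely also sits at the limit of this assay. The estimate for compound 3 in this assay is 60000 nM, with a range from 20000 nM to 200000 nM, the expected step being a step that the limit leaves unreadable from compound 2 to compound 3.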

Compound 3, half-maximal inhibitory concentration: > 50000 nM
Compound 3 gave a limit, no number (the forecaster's own chance of this, stated with the estimate: 85%); the middle value does not contradict the limit.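

No size can be read for the change from compound 2 to compound 3 or from compound 1 to compound 3, because all three compounds give a limit rather than a number: the limit of > 50000 nM in this assay, at which 3 of the 3 values shown sit.

The compounds shown leave open how they truly differ from one another, and which change to the shared core, if any, would give a measurable value in this assay.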